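A few compounds are considered here, and "the series" means these few. Any claim that something is new, unique, unknown or untested is made for them only; others in the source may bear on it.

In a functional assay on MGC-803 cells (Homo sapiens) for inhibition, read by MTT assay, with a stated time of 72 h (on this read-out higher numbers stand for weaker inhibition and lower numbers for stronger inhibition), compound 3 `Cc1cc(N2CC[C@@H](C)[C@@H](N(C)c3ncnc4[nH]ccc34)C2)n2nc(SCc3ccccc3Br)nc2n1` gives 27000 nM, the second highest of the three numbers recorded. Its nearest neighbour is compound 1 `Cc1cc(N2CC[C@@H](C)[C@@H](N(C)c3ncnc4[nH]ccc34)C2)n2nc(SCC3CCCCC3)nc2n1`, which in this assay gives 9170 nM; the furthest is compound 2 `CCc1cc(N2CC[C@@H](C)[C@@H](N(C)c3ncnc4[nH]ccc34)C2)n2ncnc2n1`, which gives 80200 nM. For the measured compounds named here, only one measured step touches the same position: a 2.9-fold higher number from compound 1 to compound 3 (0.47 log units; beyond the scatter). The next compound, compound 4 `Cc1cc(N2CC[C@@H](C)[C@@H](N(C)c3ncnc4[nH]ccc34)C2)n2nc(SCCCc3ccccc3)nc2n1`, differs from compound 3 in one place: phenethyl in place of 2-bromophenyl on a saturated chain carbon bound to a sulfur. Going by the values given here, no measured pair shows exactly this exchange, so the expectation rests on the single step from compound 1 to compound 3 and on the spread between compound 1 and compound 2, which brackets where a flexible chain bearing a plain aromatic ring might land. Compound 4 is therefore expected to sit between compound 1 and compound 3, with an estimated step of a 1.8-fold lower number from compound 3 to compound 4 (0.26 log units; within the scatter) in this assay. The estimate for compound 4 in this assay is 15000 nM, with a range from 5000 nM to 45000 nM.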

Compound 4, half-maximal inhibitory concentration: > 100000 nM
Compound 4 ended at the assay's limit; the forecaster's own chance of this, stated with the estimate: 5%; middle value at least 6.6-fold (0.82 log units) from the limit.
By their numbers in this assay, from the lowest: compound 1; then compound 3; then compound 2. At a limit, above all of these: compound 4.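

In this assay compound 4 gives > 100000 nM as its reading, which is a limit of the assay and not a number: the limit of > 100000 nM in this assay, at which 1 of the 4 values shown sits. On a saturated chain carbon bound to a sulfur, phenethyl in place of 2-bromophenyl comes with an at least 3.7-fold higher number from compound 3 to compound 4 (0.56 log units; beyond the scatter) and phenethyl in place of cyclohexyl with an at least 10-fold higher number from compound 1 to compound 4 (1.03 log units; beyond the scatter) in this assay. Compound 1 and compound 3 had shown only that this position tolerates a change of ring with a modest step, whereas compound 4 shows that an aromatic ring in itself does not keep the reading clear of the limit.

This exchange both removes the bromine and lengthens the chain, and the compounds shown do not separate the two. From the compounds shown here alone, a plain benzyl group, or an amine or a carboxylic acid at the end of the 3-phenylpropyl chain, remains open.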